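Chloro on the fused carbocycle of compound 1: the second position

This account rests on a few compounds, and the source may have more. Where it says the series, first, only, none or still open, it means among the compounds named here.

Measured so far:
- compound 1 `O=c1oc(Nc2ccccc2I)nc2ccccc12`: in an assay on isolated protein for inhibition of complement C1r subcomponent (Homo sapiens) (on this read-out higher numbers stand for weaker inhibition and lower numbers for stronger inhibition), compound 1 gives 3500 nM
- compound 2 `Cc1ccccc1Nc1nc2ccccc2c(=O)o1`: in this assay compound 2 gives 31000 nM
- compound 3 `O=c1oc(Nc2ccccc2I)nc2ccc(Cl)cc12`: in this assay compound 3 gives 4000 nM

Compound 1 has the lowest number of the three. Compound 3 sits within the scatter of it, whereas compound 2 lies well apart: an 8.9-fold higher number from compound 1 to compound 2 (0.95 log units; beyond the scatter). The step to compound 4 `O=c1oc(Nc2ccccc2I)nc2cc(Cl)ccc12` is chloro in place of hydrogen on an aromatic carbon. Among the measured compounds shown here, the one step that bears on it is the other chloro placement, a 1.1-fold higher number from compound 1 to compound 3 (0.06 log units; within the scatter), which stayed within the scatter; on that basis no shift beyond the scatter is expected here, so a 1.1-fold higher number from compound 1 to compound 4 (0.04 log units; within the scatter) is the estimated step. For compound 4 the expected value in this assay is 3800 nM, with a range from 1800 nM to 8500 nM.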

Compound 4, half-maximal inhibitory concentration: 700 nM
Compound 4: middle estimate off by 5.4-fold (0.73 log units), on the high side, and the stated range ends above it.
By their numbers in this assay, from the lowest: compound 4; then compounds 1 and 3 (each within the scatter of the next); then compound 2.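

In this assay, chloro on the aromatic ring of carbon only does not read the same at every carbon: the step here is a 5.0-fold lower number from compound 1 to compound 4 (0.70 log units; beyond the scatter), whereas the other placement gave a 1.1-fold higher number from compound 1 to compound 3 (0.06 log units; within the scatter). The change of group is identical in both steps, so among these compounds the outcome depends on placement. Nothing measured here accounts for the difference.

Still open, from the compounds shown here alone, is whether a fluoro, a methoxy or a carboxylic acid on the same carbon would lower the number as chloro does. Also open, going by these compounds, is how chloro at this carbon behaves alongside the methyl of compound 2 in place of iodo.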